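Chloro for trifluoromethyl in a two-compound series

The source may report more compounds than this note shows. Statements on the series, on what has been measured and on what is new or still open speak of the compounds shown alone.

Compound 1 `Cc1cn(-c2cc(NC(=O)c3ccc(C)c(Nc4nc(-c5cccnc5)cs4)c3)cc(C(F)(F)F)c2)cn1` is one of two measured members of the series. In a functional assay on K562 cells (Homo sapiens) for antiproliferative activity (a higher number here means a weaker inhibitor, a lower number a stronger inhibitor), compound 1 gives 1830 nM, the highest of the two numbers recorded so far. Compound 2 `Cc1ccc(C(=O)Nc2cccc(C(F)(F)F)c2)cc1Nc1nc(-c2cccnc2)cs1`, which lacks the 4-methyl-1H-imidazol-1-yl group, gives 1440 nM in this assay; the step of a 1.3-fold lower number from compound 1 to compound 2 (0.10 log units; within the scatter) is within the scatter, so the two numbers cannot be told apart.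

Compound 3 `Cc1cn(-c2cc(Cl)cc(NC(=O)c3ccc(C)c(Nc4nc(-c5cccnc5)cs4)c3)c2)cn1` has not yet been measured. It differs from compound 1 in one place: chloro in place of trifluoromethyl on an aromatic carbon. Among the measured compounds shown here, no measured step bears on this exchange: the only step recorded, from compound 1 to compound 2, concerns removal of the 4-methyl-1H-imidazol-1-yl group rather than the trifluoromethyl group, and it was itself within the scatter. For the measured compounds named here, with no precedent for the exchange and both measured numbers lying close together, no step beyond the scatter is expected in this assay in either direction. Compound 3 is therefore expected to give about 1800 nM in this assay, with a plausible range from 700 nM to 4500 nM. The expected step of a 1.0-fold lower number from compound 1 to compound 3 (0.01 log units; within the scatter) is thus essentially flat.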

Compound 3, half-maximal inhibitory concentration: 2360 nM
For compound 3 the middle estimate is 1.3-fold (0.12 log units) below the measured one; measured number inside the range.
By their numbers in this assay, from the lowest: compounds 2, 1 and 3 (each within the scatter of the next).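

Working notes on the trifluoromethyl position: in this assay, chloro in place of trifluoromethyl gives a 1.3-fold higher number from compound 1 to compound 3 (0.11 log units; within the scatter), so a substituent of 1 heavy atom and one of 4 heavy atoms cannot be told apart at this position, on an aromatic carbon meta to the 4-methyl-1H-imidazol-1-yl group. Among the compounds shown here, the earlier pair varied only the 4-methyl-1H-imidazol-1-yl group, so this is the first reading at the trifluoromethyl position, and within these three compounds neither single change on this ring separates the numbers. No measurement shown explains this flat result at the position.

Chloro and trifluoromethyl both count 0 hydrogen-bond donors and 0 hydrogen-bond acceptors, so it remains open whether an amine, a carboxylic acid or a methoxy group at this position would give a step beyond the scatter. Also open, on these data alone, is whether the flat reading holds when the 4-methyl-1H-imidazol-1-yl group is replaced by a morpholine ring or a longer chain, since the exchange has been read only with that group in place.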